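Homologation of the oxane amide in phenylethynyl thiazolopyridines

The source may report more compounds than this note shows. Statements on the series, on what has been measured and on what is new or still open speak of the compounds shown alone.

Compound 1 `CC1CC(C(=O)N2CCc3nc(C#Cc4ccccc4)sc3C2)C1`, in an assay on HEK293 cells for negative allosteric modulation of metabotropic glutamate receptor 5 (Homo sapiens), read by FLIPR, with a stated time of 1 h (on this read-out higher numbers stand for weaker inhibition and lower numbers for stronger inhibition), reports only the assay limit > 10000 nM for compound 1.
Compound 2 `O=C(C1CCCCO1)N1CCc2nc(C#Cc3ccccc3)sc2C1`, in this assay, reports only the assay limit > 10000 nM for compound 2.

The step from compound 1 to compound 2 is a step that the two limits leave unreadable from compound 1 to compound 2, so compound 2 stands at the limit shared by both measured values, as the limit of > 10000 nM in this assay, at which 2 of the 2 values shown sit, shows. Compound 3 `O=C(CC1CCOCC1)N1CCc2nc(C#Cc3ccccc3)sc2C1` differs from compound 2 by (oxan-4-yl)methyl in place of oxan-2-yl on a carbonyl carbon. Within the data shown here, the one measured step offers no readable size, so for compound 3 in this assay no shift beyond the scatter is expected, and the step from compound 2 to compound 3 is estimated as a step that the limit leaves unreadable from compound 2 to compound 3. Compound 3 is expected to give about 15000 nM, within 3000 nM to 60000 nM.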

Compound 3, half-maximal inhibitory concentration: > 10000 nM
Compound 3: no number, only a limit; the forecaster's own chance of this, stated with the estimate: 80%; the middle value is on the limit's open side.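

Compound 3 gives only the assay limit > 10000 nM in this assay, so its steps from compound 1 and compound 2 cannot be read. The compounds shown leave open whether any group on this carbonyl carbon gives a measurable value in this assay.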